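Benzyl to Phenoxy: Cytotoxicity in Ava5 Cells

The source may hold more compounds than are shown below. What is called first, only, known or untested is meant among the compounds shown, and "the series" means these compounds.

Compound 1, `NC(=S)Nc1cccc(OCCCCCOc2ccccc2)c1`, gives > 50000 nM in an ADME assay on Ava5 cells (Homo sapiens) for cytotoxicity; on this read-out lower numbers stand for higher toxicity in this test and higher numbers for lower toxicity in this test; this is a limit of the assay, not a number.
Compound 2, `NC(=S)Nc1cccc(OCCCCCOc2cccc(Cc3ccccc3)c2)c1`, gives 13000 nM in the same test.

Compound 2 holds the only true number shown in this assay. The other value belongs to compound 1 and is the limit of > 50000 nM in this assay, at which 1 of the 2 values shown sits. Compound 3, `NC(=S)Nc1cccc(OCCCCCOc2cccc(Oc3ccccc3)c2)c1`, has not yet been measured. It differs from compound 2 by phenoxy in place of benzyl on an aromatic carbon. For the measured compounds named here, the one measured step at this position, an at least 3.8-fold lower number from compound 1 to compound 2 (0.58 log units; beyond the scatter), shows that placing a benzyl group there made the number smaller. The change to compound 3 exchanges that benzyl for a phenoxy group carrying the same kind of six-membered aromatic ring of carbon only, so no step beyond the scatter is expected. Compound 3 is therefore expected to give about 13000 nM, within 6000 nM to 30000 nM. The implied step, no change at the digits printed from compound 2 to compound 3 (within the scatter), is expected to stay within the scatter.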

Compound 3, half-maximal cytotoxic concentration: 18000 nM
For compound 3 the middle estimate is 1.4-fold (0.14 log units) below the measured one, and the stated range covers the measured number.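

In this assay, putting phenoxy in place of benzyl gives a 1.4-fold higher number from compound 2 to compound 3 (0.14 log units; within the scatter), so at this place the exchange of benzyl for phenoxy, which adds one hydrogen-bond acceptor, yields values that cannot be told apart. Phenoxy in place of hydrogen gives an at least 2.7-fold lower number from compound 1 to compound 3 (0.44 log units; beyond the scatter), which shows that a lower number at this place is not limited to benzyl, since both groups carrying a six-membered aromatic ring of carbon only go with one. On these data alone, the value of compound 1 is a limit and not a number, so the full size of that step stays unknown: the limit of > 50000 nM in this assay, at which 1 of the 3 values shown sits.

As far as these compounds go, whether a much smaller group here, such as methyl or a single chlorine atom, would also lower the number remains open. So does the outcome for an amine or a carboxylic acid on the added ring.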